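The source may report more compounds than this note shows. Statements on the series, on what has been measured and on what is new or still open speak of the compounds shown alone.

Compound 1, `Clc1cc(Cl)cc(CO[C@H]2CCCN(Cc3ccccn3)[C@H]2c2ccccc2)c1`, gives in an assay on isolated protein for activation of cGMP-dependent protein kinase 1 (Homo sapiens), read by ADP-Glo, with stated times of 120 min and 40 min (on this read-out higher numbers stand for an effect only at larger amounts of compound and lower numbers for an effect already at smaller amounts), only the limit > 200000 nM. Compound 2, `O=C(O)c1cncc(CN2CCC[C@H](O[C@H](CO)c3cc(Cl)cc(Cl)c3)[C@@H]2c2ccccc2)c1`, gives in this assay 34000 nM. Compound 3, `O=C(O)c1cncc(CN2CCC[C@H](OCc3cc(Cl)cc(Cl)c3)[C@@H]2c2ccccc2)c1`, gives in this assay 117000 nM.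

Compound 2 holds the lowest of the two numbers in this assay; its nearest neighbour is compound 3, with a 3.4-fold higher number from compound 2 to compound 3 (0.54 log units; beyond the scatter), while compound 1 sits at the limit of > 200000 nM in this assay, at which 1 of the 3 values shown sits.

Compound 4, `CN1CCC[C@H](O[C@H](CO)c2cc(Cl)cc(Cl)c2)[C@@H]1c1ccccc1`, differs from compound 2 at the carbon bound to the ring nitrogen: hydrogen in place of 5-carboxypyridin-3-yl on a saturated chain carbon bound to an amine nitrogen in a ring. For the measured compounds named here, the only measured step at that position is an at least 1.7-fold lower number from compound 1 to compound 3 (0.23 log units; that floor lies within the scatter), which exchanges one ring for another rather than removing it, and its floor lies within the scatter. Going by the values given here, the removal of the whole (5-carboxypyridin-3-yl)methyl group in favour of methyl is a larger change than that step, and no measured pair covers it directly. With compound 2 at 34000 nM and the step from compound 1 to compound 3 small, a modest rise in the number is expected for compound 4, though a result within the scatter would also fit what is known. Compound 4 is therefore estimated at 70000 nM in this assay, between 25000 nM and 200000 nM, which means an expected step of a 2.1-fold higher number from compound 2 to compound 4 (0.31 log units; beyond the scatter).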

Compound 4, half-maximal effective concentration: 42000 nM
Compound 4: middle estimate off by 1.7-fold (0.22 log units), on the high side; measured number inside the range.
By their numbers in this assay, from the lowest: compounds 2 and 4 (each within the scatter of the next); then compound 3. At a limit, above all of these: compound 1.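

In this assay, hydrogen in place of 5-carboxypyridin-3-yl on a saturated chain carbon bound to an amine nitrogen in a ring gives a 1.2-fold higher number from compound 2 to compound 4 (0.09 log units; within the scatter) and so leaves the two numbers indistinguishable. The earlier step at this place, an at least 1.7-fold lower number from compound 1 to compound 3 (0.23 log units; that floor lies within the scatter), only exchanged one ring for another and rested on a limit, whereas this pair shows that, with hydroxymethyl present on the other side of the molecule, the change from (5-carboxypyridin-3-yl)methyl to methyl does not take the number beyond the scatter. Nothing measured here gives a reason for this result.

Going by these compounds, what remains open is whether the same exchange to methyl would hold for compound 3, which at 117000 nM carries no hydroxymethyl, since a single pair cannot show whether the outcome depends on that group. Also open, on these data alone, is whether a group other than methyl on the ring nitrogen, such as a longer chain, a primary amine on a chain or a simple carboxylic acid on a chain without the pyridine ring, would move the number beyond the scatter.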